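Swapping Trifluoromethyl for Trifluoromethoxy in Two Related Cores

The source may hold more compounds than are shown below. What is called first, only, known or untested is meant among the compounds shown, and "the series" means these compounds.

Compound 1 `CC(O)(COc1cccc(C(F)(F)F)c1)C(=O)Nc1ccc(S(F)(F)(F)(F)F)cc1` and compound 2 `CC(O)(COc1cccc(OC(F)(F)F)c1)C(=O)Nc1ccc(S(F)(F)(F)(F)F)cc1` share one core, while compound 3 `CC(O)(COc1ccc(C(F)(F)F)cc1)C(=O)Nc1cccc(S(F)(F)(F)(F)F)c1` and compound 4 `CC(O)(COc1ccc(OC(F)(F)F)cc1)C(=O)Nc1cccc(S(F)(F)(F)(F)F)c1` share another; the difference between the two cores is not broken down here. The three measured compounds were tested in a functional assay on CWR22R cells (Homo sapiens) for antiproliferative activity, read by propidium iodide staining, with a stated time of 96 h; a lower number here means a stronger inhibitor, a higher number a weaker inhibitor. Compound 1 gives 14600 nM, and compound 2 gives 17300 nM. The change between them is trifluoromethoxy in place of trifluoromethyl on an aromatic carbon, and it made a 1.2-fold higher number from compound 1 to compound 2 (0.07 log units; within the scatter). Compound 3 stands apart from both: in this assay compound 3 gives 3600 nM, the lowest of the three numbers, and its gaps to compound 1 and to compound 2 both lie beyond the scatter.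

Compound 4 has not yet been measured. It is related to compound 3 by trifluoromethoxy in place of trifluoromethyl on an aromatic carbon. For the measured compounds named here, this is the same kind of change as the one from compound 1 to compound 2, but not the same: in compound 1 the group sits meta to a large group, whereas in compound 3 it sits para to a large group. Going by the values given here, the expected step is a 1.2-fold higher number from compound 3 to compound 4 (0.08 log units; within the scatter), because the one measured example of this swap made a 1.2-fold higher number from compound 1 to compound 2 (0.07 log units; within the scatter), a step within the scatter. Among the compounds with values here, with only that single example, and on a different core, the range is kept wide. Compound 4 is therefore expected to give about 4300 nM in this assay, most likely between 2000 nM and 9500 nM.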

Compound 4, half-maximal inhibitory concentration: 12900 nM
Beside the measured number, compound 4's estimate is 3.0-fold (0.48 log units) below it; measured number above the stated range.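

In this assay, putting trifluoromethoxy in place of trifluoromethyl on the core of compound 3 gave a 3.6-fold higher number from compound 3 to compound 4 (0.55 log units; beyond the scatter), so here the swap cost a clear part of the activity. On these two cores, the effect of the swap therefore did not carry over in size, and a step seen on one core was a poor guide to the step on the other: the same change on two cores in this assay, a 1.2-fold higher number (0.07 log units; within the scatter) from compound 1 to compound 2 and a 3.6-fold higher number (0.55 log units; beyond the scatter) from compound 3 to compound 4, 3.0-fold (0.48 log units) apart, beyond the scatter of two such steps

What this does not show is the reason for the difference, since the two cores differ in more than one place and each step rests on a single pair of compounds, so nothing here singles out which difference between the cores matters or predicts how the swap would behave on a third core. The compounds shown leave open how other groups would fare on the same aromatic carbon of the core of compound 3, such as a nitrile, a chlorine atom or a methoxy group. Also open, on these data alone, is how the swap would behave on a core that differs from either of these in only one place, a comparison that could begin to separate the features of the two cores.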